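This account rests on a few compounds, and the source may have more. Where it says the series, first, only, none or still open, it means among the compounds named here.

Working notes on the series in a functional assay on CHO cells for inhibition of Orexin/Hypocretin receptor type 1 (Homo sapiens), read by FLIPR and calcium flux; on this read-out lower numbers stand for stronger inhibition and higher numbers for weaker inhibition.

Compound 2 `CCN(C(=O)CN(c1cc(N(C)C)ccc1Cl)S(=O)(=O)c1ccc(OC)c(OC)c1)c1ccn(C)n1` gives 12 nM in this assay. Compound 1 `CCN(CC)C(=O)CN(c1cccc(N(C)C)c1C#N)S(=O)(=O)c1ccc(OC)c(OC)c1` returns only a limit of the assay, > 10000 nM. Compound 3 `CCN(CC)C(=O)CN(c1ccc(C)cc1)S(=O)(=O)c1cccc(C)c1` likewise returns only a limit, > 10000 nM. Compound 3 therefore stands at the edge of the measured range rather than at a number, a position it shares with one other compound, as the limit of > 10000 nM in this assay, at which 2 of the 3 values shown sit, records; only compound 2 returns a value within range.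

Compound 4 `CCN(CC)C(=O)CN(c1ccc(C)cc1)S(=O)(=O)c1ccc(Br)cc1` differs from compound 3 in one place: 4-bromophenyl in place of 3-methylphenyl on a sulfonyl sulfur. For the measured compounds named here, no measured pair covers this change, so no step size can be read from the data. The rest of compound 3 is kept, and compound 3 sits at the limit. The expectation is that compound 4 stays near that limit, an expected step that the limit leaves unreadable from compound 3 to compound 4, none beyond the scatter. Compound 4 is estimated at 12000 nM, range 3000 nM to 50000 nM, with a fair chance that again only a limit is reported.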

Compound 4, half-maximal inhibitory concentration: > 10000 nM
Compound 4: only a limit was reported (the forecaster's own chance of this, stated with the estimate: 75%); the middle value does not contradict the limit.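

No step can be read between compound 3 and compound 4, because both return only a limit: the limit of > 10000 nM in this assay, at which 3 of the 4 values shown sit.

The compounds shown leave open how 4-bromophenyl and 3-methylphenyl on a sulfonyl sulfur compare in a compound that returns a value within range.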